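A 2,4,6-trimethoxyphenyl variant after two limit readings

The source may hold more compounds than are shown below. What is called first, only, known or untested is meant among the compounds shown, and "the series" means these compounds.

In a functional assay on HeLa cells (Homo sapiens) for cytotoxicity, read by MTT assay, with a stated time of 48 h (on this read-out lower numbers stand for stronger inhibition and higher numbers for weaker inhibition), compound 1 `COc1ccc(/C=C/C(=O)/C=C/c2cc3ccccc3nc2Oc2ccc(Br)cc2)c(OC)c1` gives > 10000 nM, which is a limit and not a number. In this assay compound 2 `COc1ccc(/C=C/C(=O)/C=C/c2cc3ccccc3nc2Oc2ccc(Br)cc2)cc1OC` gives > 10000 nM, again a limit and not a number. Compound 2 therefore stands at the limit of > 10000 nM in this assay, at which 2 of the 2 values shown sit, with no numerical reading anywhere in the pair.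

The next compound to test is compound 3 `COc1cc(OC)c(/C=C/C(=O)/C=C/c2cc3ccccc3nc2Oc2ccc(Br)cc2)c(OC)c1`. It keeps the shared core and changes one group on a double-bonded chain carbon bound to a double-bonded chain carbon: 2,4,6-trimethoxyphenyl in place of 3,4-dimethoxyphenyl on a double-bonded chain carbon bound to a double-bonded chain carbon.

Within the data shown here, only one measured step bears on this change, since it too exchanges the substituted phenyl group at that place: a step that the two limits leave unreadable from compound 1 to compound 2. That step offers neither a size nor a direction to carry over. No step beyond the usual scatter is therefore expected in this assay, and a further limit is the likeliest report. The expected step is a step that the limit leaves unreadable from compound 2 to compound 3. For compound 3 the estimated value is 12000 nM, with an expected range from 4000 nM to 30000 nM.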

Compound 3, half-maximal inhibitory concentration: > 10000 nM
Compound 3: a limit, no number; the forecaster's own chance of this, stated with the estimate: 65%; the middle value lies beyond the limit too.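

In this assay compound 3 gives > 10000 nM, a limit and not a number. No new step can be read among compound 1, compound 2 and compound 3, which all sit at one limit: the limit of > 10000 nM in this assay, at which 3 of the 3 values shown sit.

From the compounds shown here alone, whether the 2,4-dimethoxyphenyl, 3,4-dimethoxyphenyl and 2,4,6-trimethoxyphenyl variants differ at all in this assay, and by how much, stays open.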